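The compounds below may be only part of what the source reports. "The series", "measured", "known", "first", "only" and "open" are said of these compounds alone.

Of the compounds shown here, two have been tested so far, compound 1 (`O=C(NC(=S)Nc1cccc(C(F)(F)F)c1)c1ccccc1`) and compound 2 (`CCNC(=S)Nc1cccc(C(F)(F)F)c1`). In an ADME assay on Vero 76 cells (Chlorocebus sabaeus) for cytotoxicity, read by crystal violet staining, with a stated time of 96 h (a lower number here means that less compound is tolerated, a higher number that more compound is tolerated), compound 1 gives > 100000 nM, which is a limit of the assay and not a number. In this assay compound 2 gives > 100000 nM, again a limit and not a number. Compound 2 therefore has no exact place on the scale, and the two results cannot put the compounds in any order. The next compound, compound 3 (`CC(=O)NC(=S)Nc1cccc(C(F)(F)F)c1`), has acetyl in place of ethyl on an amide-type nitrogen. The entering group brings a carbonyl, and compound 1 also carries a carbonyl. Even so, compound 1 reads > 100000 nM, a limit. With only limits to go on, no change beyond the usual scatter is expected in this assay, and a report of the same limit is the likeliest outcome. The expected step, an at least 1.1-fold lower number from compound 2 to compound 3 (0.04 log units; that floor lies within the scatter), is small and has no clear direction. For compound 3 the estimated half-maximal cytotoxic concentration is 90000 nM, with an expected range of 40000 nM to 100000 nM.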

Compound 3, half-maximal cytotoxic concentration: > 100000 nM
Compound 3: a limit, no number (the forecaster's own chance of this, stated with the estimate: 75%); middle value at least 1.1-fold (0.04 log units) away from the limit.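

In this assay no step can be read from compound 2 to compound 3 or from compound 1 to compound 3, because all three results are limits and not numbers: the limit of > 100000 nM in this assay, at which 3 of the 3 values shown sit. The compounds shown leave open at what concentration each becomes toxic to these cells, and whether acetyl in place of ethyl, or methyl in place of phenyl, changes that concentration at all.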